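Chloro in place of methoxy: compound 2 to compound 3

The compounds below may be only part of what the source reports. "The series", "measured", "known", "first", "only" and "open" are said of these compounds alone.

Measured so far in a functional assay on the whole organism for inhibition, with Rattus norvegicus as the target, read by paw edema, at a dose of 100 mg/kg by the oral route; a lower number here means less inhibition, a higher number more inhibition at the dose given (going by the name of the read-out):
compound 1, `O=C(Nc1ccc(Cl)cc1)c1c(O)c2cccnc2n(-c2ccccc2)c1=O`, 11.6%
compound 2, `COc1cccc(NC(=O)c2c(O)c3cccnc3n(-c3ccccc3)c2=O)c1`, 5.7%

Within the data shown here, compound 2 holds the lower of the two numbers, but its only neighbour is compound 1, and the gap a number 5.9 percentage points lower from compound 1 to compound 2 (within the scatter) lies within the scatter, so the two compounds cannot be ranked against each other on what is known.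

Compound 3, `O=C(Nc1cccc(Cl)c1)c1c(O)c2cccnc2n(-c2ccccc2)c1=O`, is the next member. It differs from compound 2 in one place: chloro in place of methoxy on an aromatic carbon.

Among the measured compounds shown here, the single measured step that bears on it is the one from compound 1 to compound 2, which exchanged 4-chlorophenyl for 3-methoxyphenyl on the amide-type nitrogen and moved the number by a number 5.9 percentage points lower from compound 1 to compound 2 (within the scatter), within the scatter. That step swaps both the group and its place at once, so it only loosely matches the present change, yet it gives no sign that chloro and methoxy on this ring part the numbers.

Compound 3 is therefore expected to give 9%, with a range from 2% to 20%, an expected step of a number 3.3 percentage points higher from compound 2 to compound 3 (within the scatter) that stays within the scatter.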

Compound 3, a percentage reported as inhibition, in the whole organism at one dose (the size of the read-out at that dose, not a potency): 7.6%
Beside the measured number, compound 3's estimate is 1.4 percentage points above it; low and high end bracket the measured number.
By their numbers in this assay, from the lowest: compounds 2, 3 and 1 (each within the scatter of the next).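

In this assay, the exchange of methoxy for chloro is now seen on its own, on an aromatic carbon meta to a large group: a number 1.9 percentage points higher from compound 2 to compound 3 (within the scatter), so the two groups cannot be told apart at this position. The earlier step changed both group and place at once, whereas the place of the chlorine now stands alone, with 3-chlorophenyl in place of 4-chlorophenyl on the amide-type nitrogen giving a number 4 percentage points lower from compound 1 to compound 3 (within the scatter), so these two placements cannot be told apart either. No measurement is at hand that could account for these readings.

Going by these compounds, whether a different kind of group on this ring, such as an amine, a carboxylic acid or a longer chain like butoxy, would give a number beyond the scatter of these three compounds remains open. Equally open, on these data alone, is how a plain phenyl without any substituent on the amide-type nitrogen would read, which would give compound 1, compound 2 and compound 3 a common reference point.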